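From Chlorobenzyl to Methyl: A Small Swap, Open Outcome

The source may hold more compounds than are shown below. What is called first, only, known or untested is meant among the compounds shown, and "the series" means these compounds.

Compound 1 `Nc1nc(O)c2c(n1)n(C1OC(CO)[C@@H](O)[C@H]1O)c(=O)n2Cc1ccc(Cl)cc1` was tested in a functional assay on the whole organism (B cells) with Mus musculus as the target (on this read-out higher numbers stand for larger maximal responses and lower numbers for smaller maximal responses), where compound 1 gives 15%. Among the three values measured, this is the second highest. Compound 2 `C=CCn1c(=O)n(C2OC(CO[Si](C)(C)C(C)(C)C)[C@@H](O)[C@H]2O)c2nc(N)nc(O)c21` gives 5%, a number within the usual scatter of compound 1, so these two cannot be ranked. Compound 3 `CCCn1c(=O)n(C2C=CC(CO)O2)c2nc(N)nc(O)c21` gives 118%, far above compound 1 and beyond the scatter.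

Compound 4 `Cn1c(=O)n(C2OC(CO)[C@@H](O)[C@H]2O)c2nc(N)nc(O)c21` has not yet been measured; it differs from compound 1 by hydrogen in place of 4-chlorophenyl on a saturated chain carbon bound to an aromatic nitrogen. Going by the values given here, no measured pair shows this change alone. Because compound 3 gives 118%, a rise is expected, although compound 3 also differs in its sugar. The step is expected to be a number 15 percentage points higher from compound 1 to compound 4 (beyond the scatter), upward and beyond the scatter. Compound 4 is expected to give 30%, within a range from 5% to 80%.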

Compound 4, largest response reached (reported as maximal response), in percent of the reference or control that the assay uses: 99%
Compound 4: middle estimate off by 69 percentage points, on the low side; the whole stated range lies below it.
By their numbers in this assay, from the lowest: compounds 2 and 1 (each within the scatter of the next); then compound 4; then compound 3.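

In this assay, the change from 4-chlorobenzyl to methyl gives a number 84 percentage points higher from compound 1 to compound 4 (beyond the scatter). Going by these compounds alone, this is the first pair that differs in one place only, with the sugar unchanged, so the size of the maximal response clearly depends on the group at this position. No measured evidence here explains why the response changes with this swap.

Still open, going by these compounds, is how the response runs between these two groups. An ethyl group or a benzyl group without chlorine at this position would help show which part of the change carries the step.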